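Sulfo to methylsulfanyl on the chain of compound 3

The source may hold more compounds than are shown below. What is called first, only, known or untested is meant among the compounds shown, and "the series" means these compounds.

Values so far in a functional assay on the whole organism with Rattus norvegicus as the target; on this read-out lower numbers stand for an effect already at smaller amounts and higher numbers for an effect only at larger amounts of compound
compound 1 `CCCn1c(=N)sc2cc(OC(F)(F)F)ccc21` gives 4.5 mg/kg
compound 2 `N=c1sc2cc(OC(F)(F)F)ccc2n1CC(=O)O` gives > 10 mg/kg (a limit)
compound 3 `N=c1sc2cc(OC(F)(F)F)ccc2n1CCS(=O)(=O)O` gives > 10 mg/kg (a limit)

Compound 3 stands at > 10 mg/kg in this assay and this is a limit of the assay, not a number. The same limit holds for compound 2, and of no use here is a step that the two limits leave unreadable from compound 2 to compound 3 among the measured steps.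

Compound 4 `CSCCn1c(=N)sc2cc(OC(F)(F)F)ccc21` differs from compound 3 at one place: methylsulfanyl in place of sulfo on a saturated chain carbon, two bonds along the chain from an aromatic nitrogen and the rest of the structure stays the same.

Among the compounds with values here, two measured steps bear on this change. The closer is an at least 2.2-fold higher number from compound 1 to compound 3 (0.34 log units; beyond the scatter) with sulfo in place of methyl at that same place. The other is an at least 2.2-fold higher number from compound 1 to compound 2 (0.34 log units; beyond the scatter) with carboxy in place of ethyl. Both lead away from compound 1, which gives 4.5 mg/kg. Both steps end at a limit. Within the data shown here, compound 4 carries neither sulfo nor carboxy, so a move back toward compound 1 is expected, although no measured compound carries methylsulfanyl. The estimated step is an at least 2.8-fold lower number from compound 3 to compound 4 (0.45 log units; beyond the scatter) toward a lower number. In this assay the estimated value for compound 4 is 3.5 mg/kg within an expected range from 1.5 mg/kg to 8 mg/kg.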

Compound 4, dose for half-maximal effect: 1 mg/kg
The estimate for compound 4 lay 3.5-fold (0.54 log units) above the measured number; the whole stated range lies above it.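

In this assay, within the data shown here, the earlier compounds showed only steps away from compound 1 at this place on the chain, and methylsulfanyl in place of methyl now gives the first step toward a lower number (a 4.5-fold lower number from compound 1 to compound 4 (0.65 log units; beyond the scatter)). With methylsulfanyl in place of sulfo the step is larger still (an at least 10-fold lower number from compound 3 to compound 4 (1.00 log units; beyond the scatter)), and (methylsulfanyl)methyl in place of carboxy gives a step of the same printed size (an at least 10-fold lower number from compound 2 to compound 4 (1.00 log units; beyond the scatter)), so compound 4 has the lowest number of the series shown, with all its steps beyond the scatter. Going by these compounds, the true size of these last two steps stays open-ended, as compound 2 and compound 3 each stand at a limit and not at a number: the limit of > 10 mg/kg in this assay, at which 2 of the 4 values shown sit.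

Open, on these data alone, is whether the sulfur of the 2-(methylsulfanyl)ethyl chain matters at all, which a 2-methoxyethyl chain or a longer chain ending in methylsulfanyl would test on the same core. Also open, as far as these compounds go, is how an amine at the end of the chain would read, and the step between compound 2 and compound 3 cannot be read.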